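A few compounds are considered here, and "the series" means these few. Any claim that something is new, unique, unknown or untested is made for them only; others in the source may bear on it.

Measured so far:
Compound 1, `CN(C(=O)c1ccccc1OCc1ccccc1)[C@@H]1CCNC1`: > 10000 nM
Compound 2, `CN(C(=O)c1ccccc1OCc1ccccc1)[C@@H]1CCC[C@H](N)C1`: 3670 nM

In an assay on HEK293 cells for inhibition of transient receptor potential cation channel subfamily M member 8 (Homo sapiens), read by FLIPR and calcium flux (a lower number here means a stronger inhibitor, a higher number a weaker inhibitor), compound 1 gives > 10000 nM, which is a limit of the measurement rather than a number; this is the limit of > 10000 nM in this assay, at which 1 of the 2 values shown sits. In this assay, going by the values given here, compound 2 gives 3670 nM, the only plain number in the set, so compound 2 stands as the single measured reference point. Among the compounds with values here, the one measured step, an at least 2.7-fold lower number from compound 1 to compound 2 (0.43 log units; beyond the scatter), concerned the ring attached to the amide-type nitrogen.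

Compound 3, `N[C@H]1CCC[C@@H](N(C(=O)c2ccccc2OCc2ccccc2)C2CCC2)C1`, is built from compound 2 by cyclobutyl in place of methyl on an amide-type nitrogen. Within the data shown here, no measured step touches that methyl, so this change has no direct precedent here; the step of an at least 2.7-fold lower number from compound 1 to compound 2 (0.43 log units; beyond the scatter) altered a different group on the same nitrogen and cannot be carried over. With nothing to point either way, no step beyond the scatter is expected. Compound 3 is therefore estimated to give 3000 nM, with a range from 700 nM to 12000 nM. The expected step is a 1.2-fold lower number from compound 2 to compound 3 (0.09 log units; within the scatter), lying within the scatter.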

Compound 3, antagonist equilibrium constant: 794 nM
The estimate for compound 3 lay 3.8-fold (0.58 log units) above the measured number, within the range that was stated.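

Until now, the methyl on the amide-type nitrogen had not been varied, and only the ring on that nitrogen had changed. With cyclobutyl in place of that methyl, this assay shows a 4.6-fold lower number from compound 2 to compound 3 (0.66 log units; beyond the scatter), so this position affects the read-out as well. It also accepts a group of four carbons in a ring in place of methyl, and the number falls rather than rises, making compound 3 a stronger inhibitor than compound 2. Nothing measured here explains why this replacement lowers the number.

With only one replacement shown, it remains open whether the ring itself matters or whether the extra carbon atoms alone would do the same; an open chain such as isopropyl or n-butyl, a larger ring such as cyclopentyl, or an oxygen-containing ring such as oxetane would help to separate these possibilities. As far as these compounds go, it is also open whether cyclobutyl would lower the number in the same way with pyrrolidin-3-yl in place of 3-aminocyclohexyl, since the effect has been seen only alongside 3-aminocyclohexyl.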